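Nitrophenyl-to-benzyl amide change in the anilinomethyl-imidazole series

A few compounds are considered here, and "the series" means these few. Any claim that something is new, unique, unknown or untested is made for them only; others in the source may bear on it.

Measured in a functional assay on NIH3T3 cells (Mus musculus); on this read-out higher numbers stand for an effect only at larger amounts of compound and lower numbers for an effect already at smaller amounts:
- compound 1 `COC(=O)[C@H](CCSC)NC(=O)c1ccc(CNCc2c[nH]cn2)cc1-c1ccccc1C`: 25 uM
- compound 2 `CSCC[C@H](NC(=O)c1ccc(NCc2cncn2Cc2ccccc2C#N)cc1-c1ccccc1)C(=O)O`: > 10 uM, a limit of the assay
- compound 3 `N#Cc1ccc(Cn2cncc2CNc2ccc(C(=O)Nc3cccc([N+](=O)[O-])c3)c(-c3ccccc3)c2)cc1`: > 10 uM, a limit of the assay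

Compound 3 thus stands at the limit of > 10 uM in this assay, at which 2 of the 3 values shown sit, so no number is known for it, only that its effect was not reached. Compound 4 `N#Cc1ccc(Cn2cncc2CNc2ccc(C(=O)NCc3ccccc3)c(-c3ccccc3)c2)cc1` carries benzyl in place of 3-nitrophenyl on an amide-type nitrogen; the 3-nitrophenyl group on the amide-type nitrogen gives way to benzyl. Going by the values given here, no measured pair covers this change, so no direction beyond the scatter is expected; compound 4 is expected to sit near the same limit region, with a step that the limit leaves unreadable from compound 3 to compound 4 in this assay that is essentially none. The estimate for compound 4 is 20 uM, within 5 uM to 80 uM.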

Compound 4, concentration for half-maximal effect: > 10 uM
Compound 4 was reported as a limit (the forecaster's own chance of this, stated with the estimate: 60%); the middle value is on the limit's open side.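

In this assay, compound 3 and compound 4 both stand at a limit, so no step can be read for benzyl in place of 3-nitrophenyl: the limit of > 10 uM in this assay, at which 3 of the 4 values shown sit.

The compounds shown leave open what concentration either compound needs for half-maximal effect, and how the two amide groups compare.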